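A few compounds are considered here, and "the series" means these few. Any claim that something is new, unique, unknown or untested is made for them only; others in the source may bear on it.

Measured so far:
- compound 1 `O=C(Nc1cccc(/C=C/C(=O)c2nc3ccccc3[nH]2)c1)c1ccccc1`: 8340 nM
- compound 2 `Cc1ccccc1C(=O)Nc1cccc(/C=C/C(=O)c2nc3ccccc3[nH]2)c1`: 8290 nM

In a functional assay on 143B cells (Homo sapiens) for antiproliferative activity, read by MTT assay, with a stated time of 48 h (on this read-out higher numbers stand for weaker inhibition and lower numbers for stronger inhibition), compound 1 gives 8340 nM and compound 2 gives 8290 nM. Going by the values given here, the two numbers stand together; the only measured step, a 1.0-fold lower number from compound 1 to compound 2 (0.00 log units; within the scatter), is a methyl in place of hydrogen on an aromatic carbon and does not separate them, so compound 2 stands at no distance from compound 1 on this series.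

Compound 3 `Cc1cccc(S(=O)(=O)Nc2cccc(/C=C/C(=O)c3nc4ccccc4[nH]3)c2)c1` differs from compound 2 by (3-methylphenyl)sulfonyl in place of (2-methylphenyl)carbonyl on a nitrogen on an aromatic ring. Among the compounds with values here, no measured step covers this change: the single step known, from compound 1 to compound 2, concerns only a methyl on the aromatic ring and was within the scatter, while here the whole group on the ring nitrogen is exchanged. The step of a 1.0-fold lower number from compound 2 to compound 3 (0.02 log units; within the scatter) is therefore expected to be small, with no direction supported beyond the scatter, and the range is kept wide. For compound 3 in this assay a value of 8000 nM is estimated, between 2500 nM and 25000 nM.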

Compound 3, half-maximal inhibitory concentration: 791 nM
Beside the measured number, compound 3's estimate is 10-fold (1.00 log units) above it; the measured number lies below the stated range.
By their numbers in this assay, from the lowest: compound 3; then compounds 2 and 1 (each within the scatter of the next).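

In this assay, going by these compounds alone, the group on the nitrogen on an aromatic ring is the first place where a change separates the numbers: a 10-fold lower number from compound 2 to compound 3 (1.02 log units; beyond the scatter), and an 11-fold lower number from compound 1 to compound 3 (1.02 log units; beyond the scatter), against a 1.0-fold lower number from compound 1 to compound 2 (0.00 log units; within the scatter) for the methyl alone. Both large steps swap a carbonyl-linked group for a sulfonyl-linked one on the same nitrogen, and they agree whether the group that leaves is benzoyl or (2-methylphenyl)carbonyl. Within the data shown here, nothing available bears on why this exchange moves the number so far.

The exchange alters the linking group and the methyl's ring position together, so the compounds shown cannot say which of the two carries the step. Also open, going by these compounds, is how the number would read with a plain methylsulfonyl group or with a carboxylic acid on the aryl ring.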